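The source may hold more compounds than are shown below. What is called first, only, known or untested is meant among the compounds shown, and "the series" means these compounds.

Measured in a functional assay on PC-12 cells (Rattus norvegicus) for cytotoxicity, read by MTT assay, with stated times of 3 h and 2 h, tested at 1 uM; a lower number here means a weaker effect, a higher number a stronger effect of the compound at the concentration tested:
Compound 1 `O=C(CCCCC1CCSS1)NCc1cn(CCCCOc2ccc3cc(-c4ccccc4)c(=O)oc3c2)nn1`: 34.8%
Compound 2 `COc1ccc(-c2cc3ccc(OCCCCn4cc(CNC(=O)CCCCC5CCSS5)nn4)cc3oc2=O)cc1`: 36.8%
Compound 3 `O=C(CCCCC1CCSS1)NCc1cn(CCCCCOc2ccc3cc(-c4ccccc4)c(=O)oc3c2)nn1`: 30.7%

Compound 1 and compound 2 differ in one place: methoxy in place of hydrogen on an aromatic carbon. In this assay this change gave a number 2 percentage points higher from compound 1 to compound 2 (within the scatter). How the core of compound 1 and the core of compound 3 differ is not broken down here; compound 3 sits within the scatter of both compound 1 and compound 2 in this assay.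

Compound 4 `COc1ccc(-c2cc3ccc(OCCCCCn4cc(CNC(=O)CCCCC5CCSS5)nn4)cc3oc2=O)cc1` is not yet measured. It differs from compound 3 by methoxy in place of hydrogen on an aromatic carbon, the same change as from compound 1 to compound 2, at the same place. From compound 3 to compound 4 a step of a number 2 percentage points higher from compound 3 to compound 4 (within the scatter) is expected in this assay, because a number 2 percentage points higher from compound 1 to compound 2 (within the scatter) lay within the scatter. Compound 4 is estimated at 32.7% in this assay, expected between 24% and 42%.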

Compound 4, a percentage reported as activity, at one concentration (the size of the read-out at that concentration, not a potency): 37.1%
For compound 4 the middle estimate is 4.4 percentage points below the measured one, within the range that was stated.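

In this assay the change from phenyl to 4-methoxyphenyl gave a number 6.4 percentage points higher from compound 3 to compound 4 (within the scatter) and so carries over to the core of compound 3 without a detectable difference between cores. The two steps agree within the scatter: the same change on two cores in this assay, a number 2 percentage points higher (within the scatter) from compound 1 to compound 2 and a number 6.4 percentage points higher (within the scatter) from compound 3 to compound 4, 4.4 percentage points apart, within the scatter of two such steps
Neither step shows an effect of the methoxy group itself, and two cores cannot establish that the change behaves alike across the wider series.

Still open, from the compounds shown here alone, is whether another group at this place, such as an amine or a carboxylic acid, would move the read-out beyond the scatter. Also open, going by these compounds, is whether a longer chain than that of compound 3 and compound 4 would do so.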